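The compounds below may be only part of what the source reports. "The series", "measured", "known", "first", "only" and "open" are said of these compounds alone.

Of the compounds shown here, three built on one shared core have been tested in a functional assay on NIH3T3 cells (Mus musculus); on this read-out higher numbers stand for an effect only at larger amounts of compound and lower numbers for an effect already at smaller amounts. Compound 1 `COC(=O)[C@H](CCSC)NC(=O)c1ccc(NCc2cncn2Cc2ccc(Cl)cc2)cc1-c1ccccc1` gives in this assay > 10 uM, which is a limit of the measurement rather than a number. Compound 2 `COC(=O)[C@H](CCSC)NC(=O)c1ccc(NCc2cncn2Cc2ccc(C#N)cc2)cc1-c1ccccc1` gives > 10 uM, again only a limit. Compound 3 `COC(=O)[C@H](CCSC)NC(=O)c1ccc(NCc2cncn2Cc2ccccc2C#N)cc1-c1ccccc1` gives > 10 uM, also a limit. Because every value shown sits at the limit of > 10 uM in this assay, at which 3 of the 3 values shown sit, none of the steps between these compounds can be sized: a step that the two limits leave unreadable from compound 1 to compound 2, a step that the two limits leave unreadable from compound 1 to compound 3 and a step that the two limits leave unreadable from compound 2 to compound 3 all remain unreadable. Compound 3 therefore stands at the limit together with the other two, and no ordering among them is possible.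

Compound 4 `COC(=O)[C@H](CCSC)NC(=O)c1ccc(NCc2cncn2Cc2cccc(C)c2)cc1-c1ccccc1` differs from compound 3 by 3-methylphenyl in place of 2-cyanophenyl on a saturated chain carbon bound to an aromatic nitrogen. The two steps already described that end at compound 3 are both unreadable, so neither direction nor size can be drawn from them for this change. The expectation for compound 4 is that the step that the limit leaves unreadable from compound 3 to compound 4 will again most likely stay outside what this assay resolves. Compound 4 is estimated at 15 uM, within 5 uM to 50 uM, with a limit being the most probable report.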

Compound 4, concentration for half-maximal effect: > 10 uM
Compound 4 ended at the assay's limit (the forecaster's own chance of this, stated with the estimate: 75%); the middle value is on the limit's open side.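

Compound 4 gives > 10 uM, which is a limit and not a number. Its steps to compound 1, compound 2 and compound 3 therefore cannot be read: the limit of > 10 uM in this assay, at which 4 of the 4 values shown sit.

The compounds shown leave open whether their benzyl groups differ at all in this assay, and at what concentration any of the four takes effect.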